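The compounds below may be only part of what the source reports. "The series", "measured", "known", "first", "only" and "open" are said of these compounds alone.

Measured in an in vivo ADME assay on the whole organism for pharmacokinetics, with Rattus norvegicus as the target; a lower number here means that more of the compound stays in the plasma, a higher number that more of the compound sits outside the plasma:
Compound 1 `CN(C)C(=O)c1cc(Cl)c(NC(=O)N2CCN3C(=O)N([C@H]4C[C@@H]4c4ccccc4)C(=O)[C@@H]3C2)c(Cl)c1` gives 2.1 L/kg.
Compound 2 `CS(=O)(=O)c1cc(Cl)c(NC(=O)N2CCN3C(=O)N([C@H]4C[C@@H]4c4ccccc4)C(=O)[C@@H]3C2)c(Cl)c1` gives 0.6 L/kg.
Compound 3 `O=C(Nc1cccnc1-c1ccccc1)N1CCN2C(=O)N([C@H]3C[C@@H]3c3ccccc3)C(=O)[C@@H]2C1` gives 6.7 L/kg.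

Compound 3 has the highest of these three numbers; compound 1 comes nearest to it and compound 2 lies furthest away. Compound 4 `O=C(Nc1cccnc1-c1cccc(Cl)c1)N1CCN2C(=O)N([C@H]3C[C@@H]3c3ccccc3)C(=O)[C@@H]2C1` differs from compound 3 in one place: chloro in place of hydrogen on an aromatic carbon. Going by the values given here, the only measured step, a 3.5-fold lower number from compound 1 to compound 2 (0.54 log units; beyond the scatter), concerns a different exchange of groups in a different pair of compounds, so it does not bear directly on the present change. Among the compounds with values here, with no measured step covering a chloro in place of hydrogen, a step of a 1.1-fold higher number from compound 3 to compound 4 (0.05 log units; within the scatter) in this assay is expected, likely within the scatter. Compound 4 is therefore estimated at 7.5 L/kg, between 3.5 L/kg and 15 L/kg.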

Compound 4, volume of distribution at steady state: 4.1 L/kg
Compound 4: the middle estimate sits 1.8-fold (0.26 log units) above what was measured; measured number inside the range.
By their numbers in this assay, from the lowest: compound 2; then compounds 1, 4 and 3 (each within the scatter of the next, the first and the last beyond it).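

On this aromatic carbon, chloro in place of hydrogen gives a 1.6-fold lower number from compound 3 to compound 4 (0.21 log units; within the scatter) in this assay and so phenyl and 3-chlorophenyl cannot be told apart in this read-out. This one exchange shows that a single chlorine at this place can be carried without a change beyond the usual scatter. Nothing available explains why the result came out this way.

As far as these compounds go, whether a larger or very different group, such as a carboxylic acid, an amine or a longer chain, would behave like chloro here remains open.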